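The source may report more compounds than this note shows. Statements on the series, on what has been measured and on what is new or still open speak of the compounds shown alone.

Compound 2 `COc1cc(Oc2cccc(Nc3ccccc3)c2)cc(OC)c1CCO` gives in a functional assay on HT-29 cells (Homo sapiens) for inhibition, read by MTT assay, with a stated time of 72 h (on this read-out lower numbers stand for stronger inhibition and higher numbers for weaker inhibition), a value of 13900 nM, the higher of the two numbers in hand; compound 1 `COc1cc(Oc2cccc(Nc3ccccc3)c2)cc(OC)c1CN[C@H](C)c1ccccc1` gives 5120 nM. Compound 3 `COc1cc(Oc2cccc(Nc3ccccc3)c2)cc(OC)c1CNCc1ccc(O)cc1` differs from compound 2 by (4-hydroxybenzyl)amino in place of hydroxymethyl on a saturated chain carbon bound to an aromatic carbon. Within the data shown here, the one step that bears on this, a 2.7-fold higher number from compound 1 to compound 2 (0.43 log units; beyond the scatter), replaced an arylalkylamino group at the same place with hydroxymethyl; the move to compound 3 restores an arylalkylamino group there, so a drop of about that size is expected. Compound 3 is therefore estimated at 5500 nM, within 2200 nM to 14000 nM, a step of a 2.5-fold lower number from compound 2 to compound 3 (0.40 log units; beyond the scatter).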

Compound 3, half-maximal inhibitory concentration: 2180 nM
The estimate for compound 3 lay 2.5-fold (0.40 log units) above the measured number, outside the stated range (below it).
By their numbers in this assay, from the lowest: compound 3; then compound 1; then compound 2.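

In this assay the step to (4-hydroxybenzyl)amino on a saturated chain carbon bound to an aromatic carbon is a 6.4-fold lower number from compound 2 to compound 3 (0.80 log units; beyond the scatter) and extends what the earlier pair showed for this place. Changing only the amine nitrogen's group, to 4-hydroxybenzyl in place of 1-phenylethyl, gives a 2.3-fold lower number from compound 1 to compound 3 (0.37 log units; beyond the scatter) and so shows that the number depends on that group too, not on the amine alone. Nothing in hand gives a cause for either step. On these data alone, what a plain benzyl or a 4-methoxybenzyl group on that nitrogen would give remains open, so the ring hydroxyl and the loss of the branching methyl cannot be told apart. As far as these compounds go, a simple primary amine at the same place is also open.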